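The source may hold more compounds than are shown below. What is called first, only, known or untested is meant among the compounds shown, and "the series" means these compounds.

Measured compounds:
compound 1, `CNC(=O)CC1CCc2cc(OC)c(OC)cc21`, in a functional assay on the whole organism (strain Wistar) for inhibition, with Rattus norvegicus as the target, read by paw edema, with stated times of 60 min and 24 h, at a dose of 100 mg/kg by the oral route; a higher number here means more inhibition at the dose given (going by the name of the read-out), a lower number less inhibition: 33.3%
compound 2, `COc1cc2c(cc1OC)C(CC(=O)NC1CCCCC1)CC2`, in this assay: 53.3%
compound 3, `COc1cc2c(cc1OC)C(CC(=O)NCc1ccccc1)CC2`, in this assay: 43.3%

On these numbers compound 3 lies in a narrow band with the other two: the step of a number 10 percentage points higher from compound 1 to compound 3 (within the scatter) and the step of a number 10 percentage points lower from compound 2 to compound 3 (within the scatter) both fall within the scatter, so the three are not clearly separated. Going by the values given here, only the step of a number 20 percentage points higher from compound 1 to compound 2 (beyond the scatter) lies beyond the scatter.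

Compound 4, `COc1cc2c(cc1OC)C(CC(=O)NCCO)CC2`, differs from compound 3 in one place: hydroxymethyl in place of phenyl on a saturated chain carbon bound to an amide-type nitrogen. Among the compounds with values here, no measured step removes a phenyl or brings in a hydroxymethyl, so none bears directly on this change. The nearest comparison is the step of a number 10 percentage points higher from compound 1 to compound 3 (within the scatter), where a phenyl enters at the same saturated chain carbon with no shift beyond the scatter; its departure is therefore not expected to move the number much, and what the entering hydroxymethyl adds cannot be judged from these data. A small step, within the scatter, is expected for a number 8.3 percentage points lower from compound 3 to compound 4 (within the scatter). Compound 4 is estimated to give 35% in this assay, with a range from 20% to 50%.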

Compound 4, a percentage reported as inhibition, in the whole organism at one dose (the size of the read-out at that dose, not a potency): 13.3%
Beside the measured number, compound 4's estimate is 21.7 percentage points above it, and the stated range ends above it.
By their numbers in this assay, from the lowest: compound 4; then compounds 1, 3 and 2 (each within the scatter of the next, the first and the last beyond it).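

At the place on a saturated chain carbon bound to an amide-type nitrogen, the exchange of phenyl for hydroxymethyl in this assay gives a number 30 percentage points lower from compound 3 to compound 4 (beyond the scatter) and so moves the number, whereas the entry of the phenyl there had shown no shift beyond the scatter. The same group also stands apart from the other two compounds, with a number 20 percentage points lower from compound 1 to compound 4 (beyond the scatter) when hydroxymethyl replaces hydrogen and a number 40 percentage points lower from compound 2 to compound 4 (beyond the scatter) when 2-hydroxyethyl replaces cyclohexyl, so compound 4 alone is separated beyond the scatter from all the others. Nothing at hand explains this drop.

As far as these compounds go, it stays open whether a plain ethyl or a 2-methoxyethyl group on the amide-type nitrogen would fall with compound 4 or with compound 3. The same holds for a 2-aminoethyl group or a carboxylic acid at the end of the chain.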